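Compound 3: replacing formyl in the bromo series

A few compounds are considered here, and "the series" means these few. Any claim that something is new, unique, unknown or untested is made for them only; others in the source may bear on it.

In a functional assay on T29Kt1 cells (Homo sapiens) for cytotoxicity, read by sulforhodamine B assay, with a stated time of 3 days (on this read-out higher numbers stand for weaker inhibition and lower numbers for stronger inhibition), compound 1 `O=Cc1cn(Cc2cccc(Br)c2)c2ccccc12` gives 1580 nM and compound 2 `O=Cc1cn(Cc2ccc(Br)c(Br)c2)c2ccccc12` gives 630 nM, the lower of the two numbers. Compound 3 `OCc1cn(Cc2ccc(Br)c(Br)c2)c2ccccc12` has hydroxymethyl in place of formyl on an aromatic carbon. Among the measured compounds shown here, the only measured step, a 2.5-fold lower number from compound 1 to compound 2 (0.40 log units; beyond the scatter), is modest and comes from bromo in place of hydrogen on an aromatic carbon. For the measured compounds named here, no measured step involves formyl, so it offers only a rough guide to size. A similarly modest move toward a higher number is expected, an estimated 1.6-fold higher number from compound 2 to compound 3 (0.20 log units; within the scatter). For compound 3 the estimate is 1000 nM, with an expected range of 300 nM to 3500 nM.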

Compound 3, half-maximal inhibitory concentration: 100 nM
For compound 3 the middle estimate is 10-fold (1.00 log units) above the measured one, and the stated range ends above it.
By their numbers in this assay, from the lowest: compound 3; then compound 2; then compound 1.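

Formyl is not required at this position on the five-membered aromatic ring: hydroxymethyl in its place gives a 6.3-fold lower number from compound 2 to compound 3 (0.80 log units; beyond the scatter), a change toward stronger inhibition. The change adds a hydrogen-bond donor and removes the double bond outside aromatic rings, and this single step cannot separate the two. No measured evidence accounts for the step.

As far as these compounds go, whether a carboxylic acid, an aminomethyl group or a methyl ether would fit this position stays open. So does whether hydroxymethyl gives a similar step with the single bromo of compound 1.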